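The source may hold more compounds than are shown below. What is called first, only, known or untested is meant among the compounds shown, and "the series" means these compounds.

Within the data shown here, in a functional assay on HEK293 cells for antagonist activity at thromboxane A2 receptor (Homo sapiens), read by fluorescence and calcium flux (on this read-out higher numbers stand for weaker inhibition and lower numbers for stronger inhibition), compound 2 `CC(C)NC(=O)NS(=O)(=O)c1cc(C#N)ccc1Oc1ccc(Br)cc1` gives 9130 nM, the highest of the two numbers measured so far. Its nearest neighbour is compound 1 `Cc1cccc(Oc2ccc(C#N)cc2S(=O)(=O)NC(=O)NC(C)C)c1`, which gives 1690 nM in this assay; the step of a 5.4-fold higher number from compound 1 to compound 2 (0.73 log units; beyond the scatter) comes from a 4-bromophenyl in place of a 3-methylphenyl on an oxygen on an aromatic ring. Compound 3 `Cc1ccccc1Nc1ccc(C#N)cc1S(=O)(=O)NC(=O)NC(C)C` has not yet been measured. It differs from compound 2 in this way: (2-methylphenyl)amino in place of 4-bromophenoxy on an aromatic carbon. Among the measured compounds shown here, only one measured step bears on this change, and it concerns the ring substituent rather than the atom that links the ring: a 5.4-fold higher number from compound 1 to compound 2 (0.73 log units; beyond the scatter) shows that a methyl-bearing phenyl went with a modestly lower number than a bromine-bearing one. Since compound 3 again carries a methylphenyl, a fall is expected, and the step of a 3.0-fold lower number from compound 2 to compound 3 (0.48 log units; beyond the scatter) is the estimate. Compound 3 is therefore expected to give 3000 nM in this assay, between 800 nM and 12000 nM.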

Compound 3, half-maximal inhibitory concentration: 10100 nM
Estimate against measurement, compound 3: 3.4-fold (0.53 log units) below; measured number inside the range.
By their numbers in this assay, from the lowest: compound 1; then compounds 2 and 3 (each within the scatter of the next).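

In this assay, a methyl on the ring does not by itself bring the number down: a 1.1-fold higher number from compound 2 to compound 3 (0.04 log units; within the scatter), so (2-methylphenyl)amino and 4-bromophenoxy cannot be told apart at this position. Compound 1 now stands alone with the lowest number, as a 6.0-fold higher number from compound 1 to compound 3 (0.78 log units; beyond the scatter), and its step to compound 2 is also beyond the scatter. That second step changes the linking atom and the place of the methyl within a single swap, so it does not show which of the two matters.

Going by these compounds, a (3-methylphenyl)amino or a (2-methylphenyl)oxy group at this position would separate those two changes, and what either would give remains open. Nothing available explains why these numbers fall as they do.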